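Removing the Methyl From a Trace Amine Receptor Agonist

The source may hold more compounds than are shown below. What is called first, only, known or untested is meant among the compounds shown, and "the series" means these compounds.

Measured so far:
- Compound 1 `Cc1ccccc1[C@H]1COC(N)=N1`: in a functional assay on HEK293 cells for agonist activity at trace amine-associated receptor 1 (Homo sapiens), read by cAMP accumulation, with a stated time of 30 min (on this read-out lower numbers stand for an effect already at smaller amounts and higher numbers for an effect only at larger amounts of compound), compound 1 gives 67 nM.
- Compound 2 `Cc1cc(Cl)ccc1[C@H]1COC(N)=N1`: in this assay compound 2 gives 11 nM.

Compound 1 stands at the highest of the two numbers shown. Its nearest neighbour is compound 2, separated by a 6.1-fold lower number from compound 1 to compound 2 (0.78 log units; beyond the scatter), where a chloro takes the place of a hydrogen on an aromatic carbon.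

Compound 3 `NC1=N[C@@H](c2ccccc2)CO1` differs from compound 1 by hydrogen in place of methyl on an aromatic carbon: the methyl leaves and a hydrogen enters on a six-membered aromatic ring of carbon only, ortho to a group of 6 heavy atoms. Among the measured compounds shown here, no measured step touches this methyl; the only step available, a 6.1-fold lower number from compound 1 to compound 2 (0.78 log units; beyond the scatter), adds a chloro elsewhere on the ring and so bears only indirectly on the change. The expectation is therefore cautious: a small step, more likely toward a higher number than a lower one, and possibly within the scatter. Compound 3 is expected to give 150 nM, with a range from 40 nM to 600 nM. This estimate corresponds to an expected 2.2-fold higher number from compound 1 to compound 3 (0.35 log units; beyond the scatter).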

Compound 3, half-maximal effective concentration: 67 nM
For compound 3 the middle estimate is 2.2-fold (0.35 log units) above the measured one; low and high end bracket the measured number.
By their numbers in this assay, from the lowest: compound 2; then compounds 1 and 3 (each within the scatter of the next).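

Replacing the methyl with a hydrogen gives no change at the digits printed from compound 1 to compound 3 (within the scatter) in this assay. The earlier step, a 6.1-fold lower number from compound 1 to compound 2 (0.78 log units; beyond the scatter), concerned a chloro elsewhere on the ring and said nothing about this carbon; the new pair shows that, in this read-out, the core of compound 1 does not depend on the methyl to hold its number. No measurement at hand offers an explanation for why the methyl can be lost without a detectable shift.

From the compounds shown here alone, whether a larger group on this carbon, such as an ethyl or a methoxy, would also leave the number in place remains open, as a methyl and a hydrogen are only two possible occupants. Also open, going by these compounds, is whether the chloro of compound 2 would bring a similar step on a ring that lacks the methyl.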